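The compounds below may be only part of what the source reports. "The series", "measured", "known", "first", "only" and "open" are said of these compounds alone.

Measured compounds:
- compound 1, `CC1CCN(C2CCN(S(=O)(=O)c3cccc(-c4ccccc4C(F)(F)F)c3)CC2)CC1`, 10 nM in a functional assay on DLD-1 cells (Homo sapiens) for antiproliferative activity, read by CellTiter-Glo, with a stated time of 72 h; on this read-out lower numbers stand for stronger inhibition and higher numbers for weaker inhibition
- compound 2, `Cc1cc(C)c(S(=O)(=O)NC2CCN(C3CCN(C)CC3)CC2)c(C)c1`, 958 nM in this assay

Compound 1 stands at the lowest of the two numbers in this assay; compound 2 sits far above it, a gap beyond the scatter. Among the compounds with values here, no step between these two has been computed, as they differ in more than one place, so the pair says only what its two values show.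

The step from compound 1 to compound 3 is followed next. Compound 3 is `CC1CCN(C2CCN(S(=O)(=O)c3cccc(-c4ccccc4)c3)CC2)CC1`, still to be measured in this assay. The structural change is hydrogen in place of trifluoromethyl on an aromatic carbon, at the place on an aromatic carbon of a six-membered aromatic ring of carbon only, ortho to a large group. Within the data shown here, no computed step between measured compounds covers a change of this kind, so the direction rests on compound 1 alone.

For compound 3 a moderate loss against compound 1 is expected in this assay, about a 3.0-fold higher number from compound 1 to compound 3 (0.48 log units; beyond the scatter), with wide uncertainty. Compound 3 is estimated at 30 nM, range 8 nM to 120 nM.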

Compound 3, half-maximal inhibitory concentration: 2 nM
Estimate against measurement, compound 3: 15-fold (1.18 log units) above, and the stated range ends above it.
By their numbers in this assay, from the lowest: compound 3; then compound 1; then compound 2.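

In this assay, hydrogen in place of trifluoromethyl on an aromatic carbon, ortho to a large group, gives a 5.0-fold lower number from compound 1 to compound 3 (0.70 log units; beyond the scatter) as a modest step beyond the scatter. Trifluoromethyl at this place is therefore not required for a low number in this series, and the plain phenyl of compound 3 at 2 nM gives the lowest number of the three compounds shown, which compound 1 on its own could not reveal. No supporting data bear on why the number falls with this change, and the observation rests on this single pair of compounds.

From the compounds shown here alone, it remains open whether the direction is specific to trifluoromethyl or would also appear with a fluorine atom, a chlorine atom, a methyl group or a methoxy group at the same place. Also open, going by these compounds, is whether an amine or a carboxylic acid on the phenyl ring of compound 3 would keep the number this low, and whether the same step would hold on a core other than that of compound 1.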